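Urea to Amide with a Dichlorophenyl Cap

A few compounds are considered here, and "the series" means these few. Any claim that something is new, unique, unknown or untested is made for them only; others in the source may bear on it.

Measured so far:
compound 1 `COc1cc(-c2nn(-c3ccc(NC(=O)Nc4cccc(Cl)c4Cl)cc3)cc2-c2ccncc2)ccc1Cl` in a functional assay on A375P cells (Homo sapiens) for antiproliferative activity, read by MTT assay, with a stated time of 48 h (on this read-out higher numbers stand for weaker inhibition and lower numbers for stronger inhibition), gives > 20000 nM
compound 2 `COc1cc(-c2nn(-c3ccc(NC(=O)Nc4ccc(Cl)c(Cl)c4)cc3)cc2-c2ccncc2)ccc1Cl` gives > 20000 nM
compound 3 `COc1cc(-c2nn(-c3ccc(NC(=O)Nc4ccc(Cl)c(C(F)(F)F)c4)cc3)cc2-c2ccncc2)ccc1Cl` gives 14000 nM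

The values of compound 1 and compound 2 are limits of the assay rather than numbers. Within the data shown here, compound 3 stands as the only compound with a measured number; its two companions sit at a limit (the limit of > 20000 nM in this assay, at which 2 of the 3 values shown sit). The step that the two limits leave unreadable from compound 1 to compound 2 cannot be read. The steps of an at least 1.4-fold lower number from compound 1 to compound 3 (0.15 log units; that floor lies within the scatter) and an at least 1.4-fold lower number from compound 2 to compound 3 (0.15 log units; that floor lies within the scatter) are each only a floor, and that floor lies within the scatter.

Compound 4 `COc1cc(-c2nn(-c3ccc(NC(=O)c4ccc(Cl)c(Cl)c4)cc3)cc2-c2ccncc2)ccc1Cl` differs from compound 3 by 3,4-dichlorophenyl in place of (4-chloro-3-(trifluoromethyl)phenyl)amino on a carbonyl carbon. Among the measured compounds shown here, no measured step covers this urea-to-amide change; the closest anchor is compound 2, which carries the same 3,4-dichlorophenyl on a urea and gives only a limit. Weak inhibition is therefore expected again, with a good chance that only a limit is reported. The estimate for compound 4 is 22000 nM, ranging from 9000 nM to 60000 nM, which means an expected step of a 1.6-fold higher number from compound 3 to compound 4 (0.20 log units; within the scatter).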

Compound 4, half-maximal inhibitory concentration: 13000 nM
Compound 4: the middle estimate sits 1.7-fold (0.23 log units) above what was measured; the measured number falls inside the stated range.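

In this assay, the carbonyl carbon can carry 3,4-dichlorophenyl directly in place of (4-chloro-3-(trifluoromethyl)phenyl)amino with no readable change, the result being a 1.1-fold lower number from compound 3 to compound 4 (0.03 log units; within the scatter). Against the two dichlorophenyl ureas there are only floors, an at least 1.5-fold lower number from compound 2 to compound 4 (0.18 log units; that floor lies within the scatter) and an at least 1.5-fold lower number from compound 1 to compound 4 (0.18 log units; that floor lies within the scatter), so the amide cannot be called better than either urea. Compound 4 joins compound 3 in giving a number, while compound 1 and compound 2 remain at a limit: the limit of > 20000 nM in this assay, at which 2 of the 4 values shown sit.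

Among the compounds shown, the urea-to-amide change with the same cap on both sides is read only against a limit, so its true size stays open. Also open, as far as these compounds go, is whether an amine or a carboxylic acid on the cap, in place of the chlorines, would move the number beyond the scatter.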